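Hydroxy for Methoxy on Two Related Ureas

A few compounds are considered here, and "the series" means these few. Any claim that something is new, unique, unknown or untested is made for them only; others in the source may bear on it.

The measured compounds, read in a functional assay on MDA-MB-468 cells (Homo sapiens) for inhibition, read by sulforhodamine B assay, with a stated time of 48 h (on this read-out lower numbers stand for stronger inhibition of growth and higher numbers for weaker inhibition of growth), are these. Compound 1 `O=C(Nc1cccc(-n2cc(-c3ccncc3)c(-c3ccc(Cl)c(O)c3)n2)c1)Nc1cccc(C(F)(F)F)c1` gives 7830 nM. Compound 2 `COc1cc(-c2nn(-c3cccc(NC(=O)Nc4cccc(C(F)(F)F)c4)c3)cc2-c2ccncc2)ccc1Cl` gives 2160 nM. Compound 3 `COc1cc(-c2nn(-c3cccc(NC(=O)Nc4ccc(Cl)c(C(F)(F)F)c4)c3)cc2-c2ccncc2)ccc1Cl` gives 4420 nM.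

Compound 3 differs from compound 2 by chloro in place of hydrogen on an aromatic carbon, a change that brought a 2.0-fold higher number from compound 2 to compound 3 (0.31 log units; beyond the scatter). Compound 1 differs from compound 2 by hydrogen in place of methyl on an oxygen on an aromatic ring, and that change brought a 3.6-fold higher number from compound 2 to compound 1 (0.56 log units; beyond the scatter). Compound 1 and compound 3 lie within the scatter of each other.

Compound 4 `O=C(Nc1cccc(-n2cc(-c3ccncc3)c(-c3ccc(Cl)c(O)c3)n2)c1)Nc1ccc(Cl)c(C(F)(F)F)c1` has not yet been measured. Going by the values given here, it differs from compound 3 by hydrogen in place of methyl on an oxygen on an aromatic ring, which is the same change, at the same place, as the one that turned compound 2 into compound 1; the cores on which it is made differ from each other only by chloro in place of hydrogen on an aromatic carbon. Because the earlier occurrence of this change gave a 3.6-fold higher number from compound 2 to compound 1 (0.56 log units; beyond the scatter) from compound 2, a step of similar size is expected here, so that compound 3 to compound 4 is estimated at a 3.2-fold higher number from compound 3 to compound 4 (0.50 log units; beyond the scatter) in this assay. On that basis compound 4 is expected to give 14000 nM, with the estimate spanning 5000 nM to 40000 nM.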

Compound 4, concentration for total growth inhibition: 1750 nM
The estimate for compound 4 lay 8.0-fold (0.90 log units) above the measured number; the measured number lies below the stated range.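

In this assay, methoxy to hydroxy did not carry over from one core to the other: on the chloro-bearing core it gave a 2.5-fold lower number from compound 3 to compound 4 (0.40 log units; beyond the scatter), in the opposite direction to the earlier step, and the two steps differ: the same change on two cores in this assay, a 3.6-fold higher number (0.56 log units; beyond the scatter) from compound 2 to compound 1 and a 2.5-fold lower number (0.40 log units; beyond the scatter) from compound 3 to compound 4, 9.2-fold (0.96 log units) apart, beyond the scatter of two such steps. Read the other way, chloro in place of hydrogen gave a 4.5-fold lower number from compound 1 to compound 4 (0.65 log units; beyond the scatter) on the hydroxy core, again opposite in direction to its step on the methoxy core: the same change on two cores in this assay, a 2.0-fold higher number (0.31 log units; beyond the scatter) from compound 2 to compound 3 and a 4.5-fold lower number (0.65 log units; beyond the scatter) from compound 1 to compound 4, 9.2-fold (0.96 log units) apart, beyond the scatter of two such steps. Across these four compounds, the two changes are therefore not additive, and the step seen on one core did not predict the step on the other, but the data do not show why this happens or which direction would be typical on further cores.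

The compounds shown leave open whether an ethoxy group or an amine in place of the hydroxy would split the same way on the two cores. They also leave open whether fluoro or methyl in place of the added chloro would reverse the step as chloro does.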